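Swapping the vinyl end of a chain on compound 2

The compounds below may be only part of what the source reports. "The series", "measured", "known", "first", "only" and "open" are said of these compounds alone.

Compound 1 `C=CCOC(=O)C1=C2C(=NC1=O)c1cccc3cccc2c13` gives 20600 nM
Compound 2 `C=CCOC(=O)C1=C2C(=NC1=O)c1cccc3c(SCCC)ccc2c13` gives 33200 nM

Both measured compounds stand level in an ADME assay on WI-38 cells (Homo sapiens) for antiproliferative activity, read by sulforhodamine B assay, with a stated time of 72 h; a lower number here means a stronger inhibitor, a higher number a weaker inhibitor (a 1.6-fold higher number from compound 1 to compound 2 (0.21 log units; within the scatter)). That step concerns propylsulfanyl, not the chain altered next. Compound 3 `CCCSc1ccc2c3c(cccc13)C1=NC(=O)C(C(=O)OCC(=O)OCC(F)(F)C(F)(F)F)=C12` differs from compound 2 on that chain ((2,2,3,3,3-pentafluoropropoxy)carbonyl in place of vinyl on a saturated chain carbon bound to an oxygen next to a carbonyl group), with (2,2,3,3,3-pentafluoropropoxy)carbonyl in place of vinyl on a saturated chain carbon bound to an oxygen next to a carbonyl group. Among the compounds with values here, no measured step covers this change, so the expectation rests on compound 2 at 33200 nM and in this assay no step beyond the scatter is expected. The expected step is small (a 1.1-fold lower number from compound 2 to compound 3 (0.04 log units; within the scatter)). For compound 3 the estimate is 30000 nM (expected range 10000 nM to 80000 nM).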

Compound 3, half-maximal inhibitory concentration: 58800 nM
For compound 3 the middle estimate is 2.0-fold (0.29 log units) below the measured one; measured number inside the range.
By their numbers in this assay, from the lowest: compounds 1, 2 and 3 (each within the scatter of the next, the first and the last beyond it).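

This is the first change shown on the chain rather than on the shared core. Putting (2,2,3,3,3-pentafluoropropoxy)carbonyl in place of vinyl gives, in this assay, a step of a 1.8-fold higher number from compound 2 to compound 3 (0.25 log units; within the scatter), so even this much larger group does not separate the pair. Nothing measured here offers an explanation for this result.

From the compounds shown here alone, whether an amine or a carboxylic acid at this place would shift the number beyond the scatter remains open. Also open, going by these compounds, is whether the same swap would behave alike in compound 1, which lacks propylsulfanyl.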